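Removing the methoxy group from compound 1

This account rests on a few compounds, and the source may have more. Where it says the series, first, only, none or still open, it means among the compounds named here.

Compound 1 `COc1ccc(/C=N/c2c(C)n(C)n(-c3ccccc3)c2=O)cc1` gives 977000000 nM in a functional assay on DLD-1 cells (Homo sapiens) for cytotoxicity, read by MTT assay, with a stated time of 72 h (a higher number here means a weaker inhibitor, a lower number a stronger inhibitor), the highest of the three numbers measured. Compound 3 `COc1ccc(/C=N/c2c(C)n(C)n(-c3ccccc3)c2=O)cc1OC` gives 676000000 nM, and compound 2 `Cc1c(/N=C/c2cccc(O)c2)c(=O)n(-c2ccccc2)n1C` gives 372000000 nM. Compound 4 `Cc1c(/N=C/c2ccccc2)c(=O)n(-c2ccccc2)n1C` is not yet measured; it differs from compound 1 by hydrogen in place of methoxy on an aromatic carbon. The step that bears most on this change is a 1.4-fold lower number from compound 1 to compound 3 (0.16 log units; within the scatter), which added a methoxy and stayed within the scatter. The other step, a 2.6-fold lower number from compound 1 to compound 2 (0.42 log units; beyond the scatter), swapped the whole aryl group and moved the number only modestly. Compound 4 is therefore expected to sit close to compound 1, with a step of a 1.0-fold higher number from compound 1 to compound 4 (0.01 log units; within the scatter) or none beyond the scatter. The estimate for compound 4 is 1000000000 nM, with a range from 450000000 nM to 2200000000 nM.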

Compound 4, half-maximal inhibitory concentration: 933000000 nM
Beside the measured number, compound 4's estimate is 1.1-fold (0.03 log units) above it; low and high end bracket the measured number.
By their numbers in this assay, from the lowest: compounds 2, 3, 4 and 1 (each within the scatter of the next, the first and the last beyond it).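

In this assay, replacing the methoxy with hydrogen gives a 1.0-fold lower number from compound 1 to compound 4 (0.02 log units; within the scatter), so on this aromatic carbon, para to a large group, compound 4 shows that the methoxy itself can be lost without a change beyond the scatter. Hydrogen in place of the hydroxy instead gives a 2.5-fold higher number from compound 2 to compound 4 (0.40 log units; beyond the scatter), which places the modest gap from the plain phenyl compound with the 3-hydroxyphenyl group of compound 2. No measurement here accounts for this difference. From the compounds shown here alone, whether an amine or a carboxylic acid on this carbon would move the number stays open. So does the outcome for a longer chain such as ethoxy.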